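The source may report more compounds than this note shows. Statements on the series, on what has been measured and on what is new or still open speak of the compounds shown alone.

Measured so far:
compound 1, `Nc1scc(-c2ccccc2)c1C(=O)c1ccccc1`: 48%
compound 2, `Nc1scc(-c2ccc(Cl)cc2)c1C(=O)c1ccccc1`: 51%

In a functional assay on CHO cells for agonist activity at adenosine receptor A1 (Homo sapiens), read by fluorescence and ERK phosphorylation, with stated times of 30 min and 1.5 h, tested at 10 uM (a higher number here means a stronger effect of the compound at the concentration tested, a lower number a weaker effect), compound 1 gives 48%, the lower of the two numbers shown, though the gap to compound 2 is within the scatter. Compound 3, `Nc1scc(-c2ccccc2)c1C(=O)c1ccc(Cl)cc1`, differs from compound 1 by chloro in place of hydrogen on an aromatic carbon. Among the compounds with values here, the only measured step that bears on this change is the one in which the same group enters the other six-membered ring: a number 3 percentage points higher from compound 1 to compound 2 (within the scatter), a difference that does not rise above the scatter. With nothing else to go on, a change of the same kind on the second ring is expected to behave alike, so compound 3 is expected to show no shift beyond the scatter, a number 2 percentage points higher from compound 1 to compound 3 (within the scatter). The estimate for compound 3 in this assay is therefore 50%, with a range from 35% to 65%.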

Compound 3, a percentage reported as activity, at one concentration (the size of the read-out at that concentration, not a potency): 64%
Beside the measured number, compound 3's estimate is 14 percentage points below it; low and high end bracket the measured number.
By their numbers in this assay, from the lowest: compounds 1 and 2 (each within the scatter of the next); then compound 3.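

In this assay, within the data shown here, the change from phenyl to 4-chlorophenyl on this ring gives a number 16 percentage points higher from compound 1 to compound 3 (beyond the scatter), so chloro at this place, para to a large group, moves the read-out, which the earlier compounds could not show. The same group on the other six-membered ring gave only a number 3 percentage points higher from compound 1 to compound 2 (within the scatter), so among these three compounds the outcome of the change depends on which ring carries the chloro. Nothing measured here explains why the two rings differ.

As far as these compounds go, whether the rise belongs to chloro in particular stays open, since fluoro, methoxy or an amine on the same carbon could behave differently. The read-out also stands at a single concentration, so it shows a stronger effect of compound 3 than of compound 1 at that concentration and leaves open how the two compare at any other.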